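Bromo-indazole amines: phenyl for methyl on the chain

The source may hold more compounds than are shown below. What is called first, only, known or untested is meant among the compounds shown, and "the series" means these compounds.

Of the compounds shown here, two have numbers so far. Compound 1 `FC(F)(F)c1cccc(CNc2cc(Br)cc3[nH]ncc23)c1` gives 16% in an assay for inhibition of Indoleamine 2,3-dioxygenase 1 (Homo sapiens), with a stated time of 1 h, tested at 10 uM; on this read-out lower numbers stand for less inhibition and higher numbers for more inhibition at the one concentration tested (going by the name of the read-out). Compound 2 `CC(C)Nc1cc(Br)cc2[nH]ncc12` gives 47% in this assay, the higher of the two numbers; compound 1 sits a number lower by more than the usual scatter, so compound 2 stands at the top of what is known.

Compound 3 `CC(Nc1cc(Br)cc2[nH]ncc12)c1ccccc1` has not yet been measured in this assay. It is reached from compound 2 by one change, (phenyl in place of methyl on a saturated chain carbon bound to a nitrogen on an aromatic ring and a saturated chain carbon), the amine on the shared core otherwise kept as it is.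

Among the compounds with values here, no pair that differs in a single place has yet been measured against each other, so the size of this step has no direct precedent. Within the data shown here, the two numbers in hand, compound 2 at 47% and compound 1 at 16%, are the only guide: the smaller substituent on the nitrogen went with the higher number. On that basis the step is expected to go downward, plausibly beyond the scatter, though a step within the scatter cannot be excluded; the expected step is a number 17 percentage points lower from compound 2 to compound 3 (beyond the scatter). For compound 3 the estimate in this assay is 30%, expected to fall between 5% and 60%.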

Compound 3, a percentage reported as inhibition, at one concentration (the size of the read-out at that concentration, not a potency): 14%
Beside the measured number, compound 3's estimate is 16 percentage points above it, within the range that was stated.
By their numbers in this assay, from the lowest: compounds 3 and 1 (each within the scatter of the next); then compound 2.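

In this assay the series now has its first pair that differs in one place, and the number moves a number 33 percentage points lower from compound 2 to compound 3 (beyond the scatter) with phenyl in place of methyl on a saturated chain carbon bound to a nitrogen on an aromatic ring and a saturated chain carbon. This shows that the position is not indifferent to the group it carries: with the rest of the amine on the shared core kept as it is, this one exchange alone takes away much of the inhibition seen at the one concentration tested. No measurement at hand bears on why the number falls, so the step stands as an observation only.

The compounds shown leave open whether the fall follows the aromatic ring itself or simply the larger count of heavy atoms, a question that cyclohexyl or ethyl in place of methyl on the same carbon would separate. They also leave open whether a group carrying a hydrogen-bond acceptor or donor at this carbon, such as hydroxymethyl or an amine-bearing chain, would hold the number of compound 2.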